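A Second Methoxycarbonyl Group on the Shared Core

A few compounds are considered here, and "the series" means these few. Any claim that something is new, unique, unknown or untested is made for them only; others in the source may bear on it.

Of the compounds shown here, two have been tested for their effect on the growth of breast cancer cells in a functional assay on MCF7 cells (Homo sapiens) for cytotoxicity, read by sulforhodamine B assay; on this read-out higher numbers stand for weaker inhibition and lower numbers for stronger inhibition. Compound 1 `CN1C[C@](C)(c2cn(C)cc2-c2c[nH]c3ccc(Cl)cc23)c2cc(Cl)ccc21` carries one indole-type arm on its core. In this assay compound 1 reaches only the limit of the assay, > 10000 nM, which is a boundary of the measurement rather than a number. Compound 2 `COC(=O)c1c(-c2c[nH]c3ccc(Cl)cc23)c(-c2c[nH]c3ccc(Cl)cc23)cn1C` carries two such arms and one methoxycarbonyl group. In this assay compound 2 likewise stops at the limit of the assay, > 10000 nM, again a boundary and not a number. Among the measured compounds shown here, both measured values therefore sit at the same place, (the limit of > 10000 nM in this assay, at which 2 of the 2 values shown sit), so no step between measured compounds can be read.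

Compound 3 `COC(=O)c1c(-c2c[nH]c3ccc(Cl)cc23)c(-c2c[nH]c3ccc(Cl)cc23)c(C(=O)OC)n1C` differs from compound 2 in one place: methoxycarbonyl in place of hydrogen on an aromatic carbon. With both known values at the limit, no change beyond the usual scatter is expected from this change, and the step from compound 2 to compound 3 is estimated as a step that the limit leaves unreadable from compound 2 to compound 3. For compound 3 the value in this assay is therefore expected near 20000 nM, within a range of 8000 nM to 60000 nM.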

Compound 3, half-maximal inhibitory concentration: > 10000 nM
Compound 3 gave a limit, no number; the forecaster's own chance of this, stated with the estimate: 85%; the middle value lies beyond the limit too.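

In this assay compound 3 gives > 10000 nM, a limit of the assay and not a number. No step from compound 2 to compound 3 can be read, because the values stop at one and the same place: the limit of > 10000 nM in this assay, at which 3 of the 3 values shown sit.

The compounds shown leave open whether methoxycarbonyl in place of hydrogen on an aromatic carbon changes cytotoxicity at all.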